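The compounds below may be only part of what the source reports. "The series", "measured", "known", "first", "only" and "open" are said of these compounds alone.

For the measured compounds named here, in a functional assay on G-361 cells (Homo sapiens) for cytotoxicity, read by fluorescence, with a stated time of 72 h (on this read-out lower numbers stand for stronger inhibition and higher numbers for weaker inhibition), compound 2 (`CC(C)c1n[nH]c2c(NCc3ccc(-c4ccccn4)cc3)nc(N[C@@H]3CCCC[C@H]3N)nc12`) gives 477 nM, the higher of the two numbers so far, and compound 1 (`CC(C)c1n[nH]c2c(NCc3ccc(-c4ccccn4)cc3)nc(NCCN)nc12`) gives 230 nM. Compound 3 (`CC(C)c1n[nH]c2c(NCc3ccc(-c4ccccn4)cc3)nc(N[C@H]3CC[C@H](N)CC3)nc12`) keeps the ring of compound 2 but carries the amine elsewhere on it: 4-aminocyclohexyl in place of 2-aminocyclohexyl on a nitrogen on an aromatic ring. Going by the values given here, no measured step covers this change. The nearest guide is a 2.1-fold higher number from compound 1 to compound 2 (0.32 log units; beyond the scatter), a modest step that replaces 2-aminoethyl with 2-aminocyclohexyl on the same nitrogen. A small shift towards lower numbers, possibly none beyond the scatter, is therefore expected. The estimated change is a 1.4-fold lower number from compound 2 to compound 3 (0.13 log units; within the scatter). For compound 3 the expected value is 350 nM, with an estimated range of 120 nM to 1000 nM.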

Compound 3, half-maximal inhibitory concentration: 745 nM
Beside the measured number, compound 3's estimate is 2.1-fold (0.33 log units) below it; the range from low to high includes it.
By their numbers in this assay, from the lowest: compound 1; then compounds 2 and 3 (each within the scatter of the next).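

Putting 4-aminocyclohexyl in place of 2-aminocyclohexyl on this nitrogen gives a 1.6-fold higher number from compound 2 to compound 3 (0.19 log units; within the scatter) in this assay, so these two placements of the amine on the ring cannot be told apart here. Set against 2-aminoethyl, 4-aminocyclohexyl gives a 3.2-fold higher number from compound 1 to compound 3 (0.51 log units; beyond the scatter), so both aminocyclohexyl compounds now stand above compound 1, with no compound shown going against this. Nothing available here accounts for these numbers.

From the compounds shown here alone, it remains open whether a longer chain such as 3-aminopropyl, or a hydroxyl in place of the amine on the 2-aminoethyl chain, would change the number of compound 1.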